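Extending the 4-methylpiperazin-1-yl tail to 4-propylpiperazin-1-yl

A few compounds are considered here, and "the series" means these few. Any claim that something is new, unique, unknown or untested is made for them only; others in the source may bear on it.

Measured in a functional assay on MDA-MB-231 cells (Homo sapiens) for cytotoxicity, read by MTT assay, with a stated time of 72 h; a lower number here means a stronger inhibitor, a higher number a weaker inhibitor:
- compound 1 `CN(C)CCCCCn1c2c(c3ccccc31)C(=O)c1c[n+]([O-])c3ccccc3c1C2=O`: 240 nM
- compound 2 `O=C1c2c[n+]([O-])c3ccccc3c2C(=O)c2c1c1ccccc1n2Cc1cn(CC(O)CO)nn1`: 1290 nM
- compound 3 `CN1CCN(CCCCn2c3c(c4ccccc42)C(=O)c2c[n+]([O-])c4ccccc4c2C3=O)CC1`: 110 nM

Compound 3 holds the lowest number of the three. The nearest measured neighbour lies at a 2.2-fold lower number from compound 1 to compound 3 (0.34 log units; beyond the scatter), and the furthest at a 12-fold lower number from compound 2 to compound 3 (1.07 log units; beyond the scatter).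

Next is compound 4 `CCCN1CCN(CCCCn2c3c(c4ccccc42)C(=O)c2c[n+]([O-])c4ccccc4c2C3=O)CC1`, with the change (ethyl in place of hydrogen on a saturated chain carbon bound to an amine nitrogen in a ring). This is ethyl in place of hydrogen, which turns methyl into propyl and gives 4-propylpiperazin-1-yl. For the measured compounds named here, no measured step alters this substituent alone. The closest guide is the modest 2.2-fold lower number from compound 1 to compound 3 (0.34 log units; beyond the scatter), a swap of a whole amine group. The steps of a 5.4-fold higher number from compound 1 to compound 2 (0.73 log units; beyond the scatter) and a 12-fold lower number from compound 2 to compound 3 (1.07 log units; beyond the scatter) are larger, but each exchanges the complete side group for one bearing 1-(2,3-dihydroxypropyl)-1H-1,2,3-triazol-4-yl, a much bigger edit than this one.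

A small change is therefore expected in this assay, with no step beyond the scatter and, if anything, a slightly higher number. The expected step is a 1.3-fold higher number from compound 3 to compound 4 (0.10 log units; within the scatter). Compound 4 is estimated at 140 nM, with an expected range of 60 nM to 350 nM.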

Compound 4, half-maximal inhibitory concentration: 2980 nM
Estimate against measurement, compound 4: 21-fold (1.33 log units) below; measured number above the stated range.
By their numbers in this assay, from the lowest: compound 3; then compound 1; then compound 2; then compound 4.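

In this assay, for the compounds shown here, the outer end of the 4-methylpiperazin-1-yl tail proves highly sensitive: ethyl in place of hydrogen, an addition of only 2 heavy atoms, gives a 27-fold higher number from compound 3 to compound 4 (1.43 log units; beyond the scatter), a larger step than any of the whole-group exchanges among the earlier compounds. The 4-propylpiperazin-1-yl tail also gives up the advantage that the piperazine tail of compound 3 held, with a 12-fold higher number from compound 1 to compound 4 (1.09 log units; beyond the scatter) and a 2.3-fold higher number from compound 2 to compound 4 (0.36 log units; beyond the scatter), so compound 4 now has the highest number of the four. Nothing available here accounts for this loss.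

The compounds shown leave open whether 4-ethylpiperazin-1-yl already carries much of the rise or stays close to compound 3. An unsubstituted piperazin-1-yl tail and a longer 4-butylpiperazin-1-yl tail would show how the number follows the length of this chain.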